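Pyridin-3-yl in place of pyridin-4-yl on the amide

This account rests on a few compounds, and the source may have more. Where it says the series, first, only, none or still open, it means among the compounds named here.

In a physicochemical assay for solubility, read by nephelometry, measured as kinetic solubility, at pH 2.0 (on this read-out higher numbers stand for higher solubility and lower numbers for lower solubility), compound 1 `CC(C)(C)c1cc(C(=O)Nc2cccc(CN)c2)n(Cc2ccccc2)n1` reads > 100 ug/mL as a limit of the assay and not a number. Compound 2 `CN(C)Cc1csc(NC(=O)c2cc(C(C)(C)C)nn2Cc2ccccc2)n1` reads > 100 ug/mL as a limit too. Compound 3 `CC(C)(C)c1cc(C(=O)Nc2ccncc2)n(Cc2ccccc2)n1` stands at > 100 ug/mL and this is again only a limit. Together they show the limit of > 100 ug/mL in this assay, at which 3 of the 3 values shown sit, and nothing finer. The change to compound 4 `CC(C)(C)c1cc(C(=O)Nc2cccnc2)n(Cc2ccccc2)n1` is pyridin-3-yl in place of pyridin-4-yl on an amide-type nitrogen and so pyridin-3-yl takes the place of pyridin-4-yl on an amide-type nitrogen. The nearest measured steps are a step that the two limits leave unreadable from compound 1 to compound 3 and a step that the two limits leave unreadable from compound 2 to compound 3 and neither offers a size to carry over. No step beyond the usual scatter is expected, in either direction, and the expected step is a step that the limit leaves unreadable from compound 3 to compound 4 in this case. Compound 4 is estimated at 110 ug/mL with a range from 55 ug/mL to 220 ug/mL and may well return only a limit.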

Compound 4, solubility: > 100 ug/mL
Compound 4 gave a limit, no number; the forecaster's own chance of this, stated with the estimate: 80%; the middle value lies beyond the limit too.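

Compound 4 joins compound 1, compound 2 and compound 3 at the same limit in this assay, so no step among these compounds can be read: the limit of > 100 ug/mL in this assay, at which 4 of the 4 values shown sit.

Going by these compounds, how compound 1, compound 2, compound 3 and compound 4 truly rank in this assay stays open.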